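A few compounds are considered here, and "the series" means these few. Any claim that something is new, unique, unknown or untested is made for them only; others in the source may bear on it.

Compound 2 `O=C1COc2ccc(-c3nn(-c4ccc(F)cc4)cc3-c3ccccc3)cc2N1` belongs to a small pair of compounds sharing one core, each bearing a substituted phenyl on the ring nitrogen of the five-membered aromatic ring. In a functional assay on DLD-1 cells (Homo sapiens) for cytotoxicity, read by colorimetric assay and MTT assay, with a stated time of 3 days, tested at 1 uM (a lower number here means a stronger effect, a higher number a weaker effect of the compound at the concentration tested), compound 2 gives 64.4%, and in the same assay compound 1 `O=C1COc2ccc(-c3nn(-c4ccc(Br)cc4)cc3-c3ccccc3)cc2N1` gives 66.4%; the only difference between them is a fluoro in place of a bromo on an aromatic carbon, and the step of a number 2 percentage points lower from compound 1 to compound 2 (within the scatter) shows that this swap made no difference that could be told from noise. So compound 2 sits side by side with compound 1, neither separable from the other.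

Compound 3 `O=C1COc2ccc(-c3nn(-c4cc(Cl)cc(Cl)c4)cc3-c3ccccc3)cc2N1` changes the same part of the molecule again: 3,5-dichlorophenyl in place of 4-fluorophenyl on an aromatic nitrogen. Going by the values given here, the one step known so far bears on this change, since it also alters the halogen pattern on that phenyl, and it was within the scatter. With nothing else to go on, no step beyond the scatter is expected in this assay in either direction. Compound 3 is therefore expected to give 63%, with a range from 45% to 80%. The estimated step is a number 1.4 percentage points lower from compound 2 to compound 3 (within the scatter).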

Compound 3, a percentage reported as activity, at one concentration (the size of the read-out at that concentration, not a potency): 90.3%
The estimate for compound 3 lay 27.3 percentage points below the measured number; measured number above the stated range.
By their numbers in this assay, from the lowest: compounds 2 and 1 (each within the scatter of the next); then compound 3.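

The phenyl on the ring nitrogen is not indifferent to what it carries in this assay: the switch to 3,5-dichlorophenyl gives a number 25.9 percentage points higher from compound 2 to compound 3 (beyond the scatter) and, measured against the bromo partner, a number 23.9 percentage points higher from compound 1 to compound 3 (beyond the scatter) in the same assay. A higher number here means a weaker effect at the concentration tested, so this change loses much of the effect, whereas exchanging one halogen for another in the 4-halophenyl pair had left nothing that could be told from noise. The position therefore responds to some changes and not to others, although this one alters the kind of halogen, the number of halogens and their places on the ring all at once, and nothing available here accounts for the loss.

Which of these alterations matters remains open, and a single chlorine, as in 4-chlorophenyl or 3-chlorophenyl, would begin to separate them. Also open, from the compounds shown here alone, is how groups of a different kind on this phenyl, such as a methoxy or an amine, would move the number, and in which direction.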